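The source may hold more compounds than are shown below. What is called first, only, known or untested is meant among the compounds shown, and "the series" means these compounds.

Compound 1, `O=C(Nc1cc(F)ccc1F)c1cc(=O)[nH]c2cc(Br)ccc12`: > 20000 nM
Compound 2, `COc1ccc(OC)c(NC(=O)c2cc(=O)[nH]c3cc(Br)ccc23)c1`: > 20000 nM
Compound 3, `O=C(Nc1cccc(F)c1)c1cc(=O)[nH]c2cc(F)ccc12`: > 20000 nM

In a functional assay on KYSE-70 cells for antiproliferative activity against KYSE-70 cell line (Homo sapiens), read by MTT assay, with a stated time of 72 h (a higher number here means a weaker inhibitor, a lower number a stronger inhibitor), compound 3 gives > 20000 nM, and this is a limit of the assay rather than a measured number. Compounds 1 and 2 sit at the same limit (the limit of > 20000 nM in this assay, at which 3 of the 3 values shown sit), so nothing can be said about the order of the three. Compound 4, `O=C(Nc1cccc(F)c1)c1cc(=O)[nH]c2cc(-c3cccnc3F)ccc12`, has not been measured. It differs from compound 3 in one place: 2-fluoropyridin-3-yl in place of fluoro on an aromatic carbon. Going by the values given here, with every measured value at the limit, there is no measured step to set the size of what should follow. In this assay the expected step is an at least 2.0-fold lower number from compound 3 to compound 4 (0.30 log units; that floor lies within the scatter), a move toward a stronger inhibitor that is only modest and carries much uncertainty. Compound 4 is estimated at 10000 nM, within a range from 2000 nM to 30000 nM.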

Compound 4, half-maximal inhibitory concentration: > 20000 nM
Compound 4: a limit, no number; the forecaster's own chance of this, stated with the estimate: 45%; at least 2.0-fold (0.30 log units) between middle value and limit.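

In this assay compound 4 gives > 20000 nM, a limit and not a number, so the step from compound 3 to compound 4 cannot be read: the limit of > 20000 nM in this assay, at which 4 of the 4 values shown sit.

Whether 2-fluoropyridin-3-yl or fluoro gives the stronger inhibitor stays open, since all four compounds shown rest at that limit.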